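The compounds below may be only part of what the source reports. "The series", "measured", "known", "first", "only" and "open" are said of these compounds alone.

Of the compounds shown here, three sharing one core have been measured in an ADME assay on microsomes (Canis lupus familiaris) for metabolic stability; a higher number here means that the compound lasts longer, a lower number that the compound disappears faster. There, compound 1 `O=c1[nH]nc2ccc(-c3ccc(Oc4ccc(F)cc4)cc3)cn12` gives 4.55 h, compound 2 `O=c1n(Cc2noc(CO)n2)nc2ccc(-c3ccc(Oc4ccc(F)cc4)cc3)cn12` gives 3.02 h and compound 3 `Cc1nc(Cn2nc3ccc(-c4ccc(Oc5ccc(F)cc5)cc4)cn3c2=O)no1` gives 2.78 h. Compound 3 cannot be separated from either of the others, since a 1.6-fold lower number from compound 1 to compound 3 (0.21 log units; within the scatter) and a 1.1-fold lower number from compound 2 to compound 3 (0.04 log units; within the scatter). The three half-lives therefore form no ranking.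

Compound 4 `Cc1nc(Cn2nc3ccc(-c4ccc(Oc5ccc(Cl)cc5)cc4)cn3c2=O)no1` departs from compound 3 in one place: chloro in place of fluoro on an aromatic carbon. The 4-fluorophenoxy group thus becomes 4-chlorophenoxy, on an aromatic carbon of a six-membered aromatic ring of carbon only, para to a large group.

For the measured compounds named here, none of the measured steps touches this halogen. The nearest evidence is indirect, as a 1.5-fold lower number from compound 1 to compound 2 (0.18 log units; within the scatter), and the two steps involving compound 3 given above are likewise small. Going by the values given here, all three changes lie elsewhere in the molecule, and the compounds measured so far include no exchange of fluoro for chloro. No direction can be drawn from them, and no step beyond the scatter is expected in this assay.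

The expected outcome is a 1.1-fold lower number from compound 3 to compound 4 (0.03 log units; within the scatter). The estimated half-life of compound 4 is 2.6 h, with an expected range from 1.4 h to 4.8 h.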

Compound 4, half-life: 5.9 h
Beside the measured number, compound 4's estimate is 2.3-fold (0.36 log units) below it; measured number above the stated range.
By their numbers in this assay, from the lowest: compounds 3, 2, 1 and 4 (each within the scatter of the next, the first and the last beyond it).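

In this assay, chloro in place of fluoro on the aromatic carbon para to a large group gives the only single-place step shown that lies beyond the scatter (a 2.1-fold higher number from compound 3 to compound 4 (0.33 log units; beyond the scatter)), a modest one. The earlier steps shown here, all made at the aromatic nitrogen or on its side chain, stayed within the scatter (a 1.5-fold lower number from compound 1 to compound 2 (0.18 log units; within the scatter); a 1.6-fold lower number from compound 1 to compound 3 (0.21 log units; within the scatter); a 1.1-fold lower number from compound 2 to compound 3 (0.04 log units; within the scatter)), so this halogen is the one place where a single exchange can be read as a change in half-life. Nothing among the data offers an explanation for this step.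

The compounds shown do not tell whether the step belongs to chloro alone, as no bromo, methyl, methoxy or trifluoromethyl group, and no plain hydrogen, appears in this position for comparison. On these data alone, it also remains open whether the same exchange would give a step of similar size on the unsubstituted core of compound 1 or alongside the hydroxymethyl side chain of compound 2.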